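The source may hold more compounds than are shown below. What is called first, only, known or untested is meant among the compounds shown, and "the series" means these compounds.

Compound 1 `Cc1c(N)c(C)c2c(c1CC(C)C)OC(C)(C)C2`: 13.3 mg/kg
Compound 2 `CCC(=O)Nc1c(C)c(C)c2c(c1C)CC(C)(C)O2`: > 100 mg/kg (a limit)

Compound 2 has no number in a functional assay on the whole organism with Mus musculus as the target (a lower number here means that less compound is needed, a higher number that more compound is needed for the effect), only the limit > 100 mg/kg. Compound 3 `Cc1c(C)c2c(c(C)c1Nc1ccc(Cl)cc1)CC(C)(C)O2` carries 4-chlorophenyl in place of propanoyl on a nitrogen on an aromatic ring. Among the compounds with values here, no measured step covers this change, so the expectation is tentative. It rests on compound 1, which gives 13.3 mg/kg in this assay. A sizeable move toward lower doses is expected, estimated as an at least 3.3-fold lower number from compound 2 to compound 3 (0.52 log units; beyond the scatter). The expected value for compound 3 is 30 mg/kg, with an estimated range of 8 mg/kg to 90 mg/kg.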

Compound 3, dose for 50% inhibition: > 50 mg/kg
Compound 3 was reported as a limit; the forecaster's own chance of this, stated with the estimate: 35%; at least 1.6-fold (0.22 log units) between middle value and limit.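

Compound 2 and compound 3 both stand only as limits in this assay; the step between them cannot be read. Still open, on these data alone, is whether 4-chlorophenyl in place of propanoyl on a nitrogen on an aromatic ring changes the dose needed at all, and in which direction.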